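The compounds below may be only part of what the source reports. "The series", "measured", "known", "first", "only" and "open" are said of these compounds alone.

Among the measured compounds shown here, in an ADME assay on microsomes from liver (Homo sapiens) for metabolic stability (a lower number here means slower removal, a higher number faster removal of the compound), compound 3 `Cc1ccc([C@H](C)NC(=O)Cn2nnc3ccccc3c2=O)c(C)c1` gives 33 mL/min/kg, the only exact number so far. Compound 1 `Cc1ccc([C@H](C)NC(=O)Cn2nnc3ccccc3c2=O)cc1` reads < 9.9 mL/min/kg, which is a limit of the assay. Compound 2 `Cc1ccc([C@H](C)NC(=O)Cn2nnc3ccccc3c2=O)cn1` reads < 9.9 mL/min/kg, also a limit. Compound 4 `C[C@H](NC(=O)Cn1nnc2ccccc2c1=O)c1ccn(C)n1` carries 1-methyl-1H-pyrazol-3-yl in place of 2,4-dimethylphenyl (1-methyl-1H-pyrazol-3-yl in place of 2,4-dimethylphenyl on a saturated chain carbon bound to an amide-type nitrogen and a saturated chain carbon). For the measured compounds named here, two measured steps bear on this change: an at least 3.3-fold higher number from compound 1 to compound 3 (0.52 log units; beyond the scatter) and an at least 3.3-fold higher number from compound 2 to compound 3 (0.52 log units; beyond the scatter), both beyond the scatter. Neither has the new group, so they offer only a rough guide, but they suggest that losing the 2,4-dimethylphenyl could reverse a rise of that size. The expectation in this assay is therefore a 3.0-fold lower number from compound 3 to compound 4 (0.48 log units; beyond the scatter) (a fall, beyond the scatter). Compound 4 is estimated at 11 mL/min/kg (range 6 mL/min/kg to 24 mL/min/kg).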

Compound 4, clearance: 12 mL/min/kg
For compound 4 the middle estimate is 1.1-fold (0.04 log units) below the measured one, and the stated range covers the measured number.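

In this assay, replacing 2,4-dimethylphenyl with 1-methyl-1H-pyrazol-3-yl at this place gives a 2.8-fold lower number from compound 3 to compound 4 (0.44 log units; beyond the scatter). Against the other two groups there are only floors, an at least 1.2-fold higher number from compound 2 to compound 4 (0.08 log units; that floor lies within the scatter) and an at least 1.2-fold higher number from compound 1 to compound 4 (0.08 log units; that floor lies within the scatter), so compound 4 may or may not truly differ from compound 1 or compound 2. Those floors rest on a limit rather than on exact numbers: the limit of < 9.9 mL/min/kg in this assay, at which 2 of the 4 values shown sit.

Going by these compounds, whether the methyl on the new ring matters remains open. A plain 1H-pyrazol-3-yl group or a thiazole ring at this place would test how far the clearance depends on that methyl or on the ring itself.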